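The source may report more compounds than this note shows. Statements on the series, on what has been measured and on what is new or still open speak of the compounds shown alone.

Measured compounds:
Compound 1 `O=C1COc2ccc(-c3cccc(NS(=O)(=O)c4ccc(F)cc4)c3)cc2N1C1CC1`: > 40000 nM
Compound 2 `COc1ccc(N2C(=O)COc3ccc(-c4ccc(O)cc4)cc32)cc1`: 17300 nM
Compound 3 `COc1ncc(-c2ccc3c(c2)N(c2ccc(F)cc2)C(=O)CO3)cc1NS(=O)(=O)c1ccc(F)cc1`: > 40000 nM

All three were tested in a functional assay on MCF7 cells (Homo sapiens) for antiproliferative activity, read by MTT assay, with a stated time of 72 h; on this read-out higher numbers stand for weaker inhibition and lower numbers for stronger inhibition. For compound 1 the value > 40000 nM is a limit of the assay, not a number. Compound 2 gives a measured number, 17300 nM. For compound 3 the value > 40000 nM is again a limit. Compound 1 therefore stands at the limit of > 40000 nM in this assay, at which 2 of the 3 values shown sit, among the weakest of the set.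

Compound 4 `CC(C)N1C(=O)COc2ccc(-c3cccc(NS(=O)(=O)c4ccc(F)cc4)c3)cc21` differs from compound 1 by isopropyl in place of cyclopropyl on an amide-type nitrogen in a ring. Within the data shown here, no pair of measured compounds differing in one place is available to set a scale for such a swap. A change of this size is expected to give no step beyond the scatter in this assay, and the expected step is a number no higher from compound 1 to compound 4 (the limit leaves the size open). Compound 4 is therefore expected to give about 40000 nM, with a range from 20000 nM to 80000 nM, most likely reported only as a limit.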

Compound 4, half-maximal inhibitory concentration: 26000 nM
Estimate against measurement, compound 4: 1.5-fold (0.19 log units) above, and the stated range covers the measured number.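

In this assay, compound 4 gives a real number at this ring nitrogen, 26000 nM, so an open isopropyl group of the same size as the cyclopropyl ring still yields a measurable result. The swap gives an at least 1.5-fold lower number from compound 1 to compound 4 (0.18 log units; that floor lies within the scatter). Its true size stays open because compound 1 gives only a limit of the assay: the limit of > 40000 nM in this assay, at which 2 of the 4 values shown sit.

The compounds shown leave open whether a longer chain, such as butyl, or a chain ending in an amine or a carboxylic acid at this nitrogen would move the number beyond the scatter.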